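From aryl to arylamino on the shared core

A few compounds are considered here, and "the series" means these few. Any claim that something is new, unique, unknown or untested is made for them only; others in the source may bear on it.

Among the compounds with values here, in a functional assay on K562 cells (Homo sapiens) for antiproliferative activity, read by MTT assay, with a stated time of 72 h (on this read-out higher numbers stand for weaker inhibition and lower numbers for stronger inhibition), compound 1 `COc1cc(C(=O)c2sc3ccccc3c2-c2ccc(Cl)cc2)cc(OC)c1OC` gives 4200 nM and compound 2 `COc1ccc(-c2c(C(=O)c3cc(OC)c(OC)c(OC)c3)sc3ccccc23)c(OC)c1` gives 4100 nM, so compound 2 stands level with the only other measured compound. The next compound is compound 3 `COc1cc(C(=O)c2sc3ccccc3c2Nc2ccc(C)cc2)cc(OC)c1OC`, with (4-methylphenyl)amino in place of 2,4-dimethoxyphenyl on an aromatic carbon. Within the data shown here, only one measured step bears on this change, and only in part: a 1.0-fold lower number from compound 1 to compound 2 (0.01 log units; within the scatter), which lies within the scatter. Among the measured compounds shown here, that step exchanges one substituted phenyl for another, and no measured compound carries an amino link at this carbon. The data therefore give no firm direction. On judgement alone, a step of a 2.7-fold lower number from compound 2 to compound 3 (0.44 log units; beyond the scatter) is expected, with wide uncertainty. In this assay the estimated value for compound 3 is 1500 nM, with an expected range of 150 nM to 7000 nM.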

Compound 3, half-maximal inhibitory concentration: 1600 nM
Compound 3: the middle estimate sits 1.1-fold (0.03 log units) below what was measured; the measured number falls inside the stated range.
By their numbers in this assay, from the lowest: compound 3; then compounds 2 and 1 (each within the scatter of the next).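

In this assay, within the data shown here, replacing a directly attached aryl group with (4-methylphenyl)amino at this carbon gives the first steps beyond the scatter, both modest (a 2.6-fold lower number from compound 2 to compound 3 (0.41 log units; beyond the scatter); a 2.6-fold lower number from compound 1 to compound 3 (0.42 log units; beyond the scatter)). The change between 4-chlorophenyl and 2,4-dimethoxyphenyl had left the number level, so this position is now seen to respond to at least one kind of exchange, with both steps running the same way. No measurement is available that would explain this result.

The compounds shown do not separate the effect of the amino link from that of the methyl on its phenyl ring. Going by these compounds, how an ether oxygen or a methylene link in place of the amino link would read stays open, as does a methoxy or chloro group in place of that methyl.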